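A few compounds are considered here, and "the series" means these few. Any claim that something is new, unique, unknown or untested is made for them only; others in the source may bear on it.

Compound 1, `Cc1c(Sc2ccc(Cl)cc2)c2cc(-c3ccccc3)ccc2n1CC(=O)O`: in an assay on isolated protein for displacement of a labelled ligand from prostaglandin D2 receptor 2 (Homo sapiens) (on this read-out lower numbers stand for stronger inhibition and higher numbers for weaker inhibition), compound 1 gives 3.5 nM.
Compound 2, `COc1ccc(Sc2c(C)n(CC(=O)O)c3ccc(C)cc23)cc1`: in this assay compound 2 gives 7.1 nM.

Of the two measured compounds, compound 2 has the higher number, and the gap between compound 1 and compound 2 is beyond the usual scatter of this assay. Within the data shown here, compound 1 and compound 2 differ in more than one place, so no single structural step between them can be read off, and their two values stand on their own.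

The unmeasured compound 3, `Cc1ccc2c(c1)c(Sc1ccc(Cl)cc1)c(C)n2CC(=O)O`, is compound 2 with one change: chloro in place of methoxy on an aromatic carbon. Nothing in the measured pair shows the effect of this exchange by itself, since compound 1 carries the chloro group on a core that differs elsewhere from that of compound 2. The expectation therefore rests on the general observation that both measured compounds sit close together, and the step is expected to be small, in either direction or none beyond the scatter. Compound 3 is expected to give about 5 nM, within a range of 2 nM to 12 nM, which corresponds to an estimated step of a 1.4-fold lower number from compound 2 to compound 3 (0.15 log units; within the scatter).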

Compound 3, half-maximal inhibitory concentration: 15 nM
Estimate against measurement, compound 3: 3.0-fold (0.48 log units) below; the measured number lies above the stated range.
By their numbers in this assay, from the lowest: compound 1; then compound 2; then compound 3.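

On the shared core of compound 2 and compound 3, going from 4-methoxyphenyl to 4-chlorophenyl gives a 2.1-fold higher number from compound 2 to compound 3 (0.32 log units; beyond the scatter) in this assay, so at this place, para to a large group, the methoxy compound is the stronger of the two, though the step is modest. Compound 3 also forms a single-change pair with compound 1, which carries the same chloro group: methyl in place of phenyl on an aromatic carbon of the core gives a 4.3-fold higher number from compound 1 to compound 3 (0.63 log units; beyond the scatter) and shows that the phenyl compound is the stronger one in this pair. Compound 1 and compound 2 could not be compared directly, but compound 3 now links them through two separate single changes, and nothing measured here explains why either change moves the number.

As far as these compounds go, whether a fluoro group, a hydroxyl or an amine at the same place would give a number closer to that of methoxy or of chloro remains open. Also open, from the compounds shown here alone, is whether chloro in place of methoxy would produce a similar step on the core of compound 1, which carries phenyl rather than methyl.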